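Chloro for fluoro on the fused ring of compound 2

The source may hold more compounds than are shown below. What is called first, only, known or untested is meant among the compounds shown, and "the series" means these compounds.

Of the compounds shown here, three have been measured in an assay for inhibition of Alpha amylase (Homo sapiens), with a stated time of 10 min; a lower number here means a stronger inhibitor, a higher number a weaker inhibitor. Compound 1 `Cc1cc2nc(-c3cc(Cl)cc(Br)c3O)[nH]c2cc1C` gives 2920 nM in this assay. Compound 2 `COc1cc(-c2nc3cc(F)ccc3[nH]2)cc(OC)c1O` gives 2490 nM in this assay. Compound 3 `COc1ccc(Br)c(-c2nc3cc(Cl)ccc3[nH]2)c1O` gives 2210 nM in this assay. The value of compound 2 lies closest to that of compound 3 and furthest from that of compound 1, yet both gaps fall within the usual scatter of repeated measurements, so the three numbers cannot be told apart on this evidence.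

Compound 4 `COc1cc(-c2nc3cc(Cl)ccc3[nH]2)cc(OC)c1O` has not yet been measured. It differs from compound 2 in one place: chloro in place of fluoro on an aromatic carbon. For the measured compounds named here, no pair of measured compounds shows this change on its own, so no step can be read directly from the data. Because compound 3, which also carries a chloro on the fused ring system, gives 2210 nM, the step from compound 2 to compound 4 is expected to be small, a 1.2-fold lower number from compound 2 to compound 4 (0.10 log units; within the scatter), and not clearly beyond the scatter. Compound 4 is therefore estimated at 2000 nM in this assay, with a range from 800 nM to 5000 nM.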

Compound 4, half-maximal inhibitory concentration: 2520 nM
Compound 4: the middle estimate sits 1.3-fold (0.10 log units) below what was measured, within the range that was stated.
By their numbers in this assay, from the lowest: compounds 3, 2, 4 and 1 (each within the scatter of the next).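

In this assay, the replacement of fluoro by chloro on this aromatic carbon can now be read directly, as a 1.0-fold higher number from compound 2 to compound 4 (0.01 log units; within the scatter). On this evidence the two halogens cannot be told apart at this position of the shared core, although that reading rests on a single pair of compounds. No other measurement shown bears on this result or offers an explanation for it.

The compounds shown leave open whether a different kind of group at this position, such as an amine or a carboxylic acid, would give a number that differs from that of compound 2 beyond the scatter. For the compounds shown here, they also leave open whether chloro in place of fluoro would give a similar result on a different core, since no second pair shows this change.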